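The source may hold more compounds than are shown below. What is called first, only, known or untested is meant among the compounds shown, and "the series" means these compounds.

In an ADME assay on MRC5 cells (Homo sapiens) for cytotoxicity, read by fluorescence, with a stated time of 72 h (on this read-out higher numbers stand for weaker inhibition and lower numbers for stronger inhibition), compound 2 `CC1(COc2ccc(C(F)(F)F)cn2)Cn2cc([N+](=O)[O-])nc2O1` reads > 64000 nM as a limit of the assay and not a number. Compound 2 therefore stands at the limit of > 64000 nM in this assay, at which 2 of the 3 values shown sit, and has no exact value. Compound 3 `O=[N+]([O-])c1cn2c(n1)OC(COc1ccc(-c3ccc(C(F)(F)F)cc3)cc1)C2` reads > 64000 nM and this too is a limit. Among the compounds with values here, compound 1 `O=[N+]([O-])c1cnc2n1CC(COc1ccc(OC(F)(F)F)cc1)O2` gives 31000 nM as the only exact value so far.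

Compound 4 `CC1(COc2ccc(-c3ccc(F)cc3)cn2)Cn2cc([N+](=O)[O-])nc2O1` carries 4-fluorophenyl in place of trifluoromethyl on an aromatic carbon, para to a large group, and the change counts as 4-fluorophenyl in place of trifluoromethyl on an aromatic carbon in full. Within the data shown here, no measured pair shows a step of this kind. Compound 3 also carries a six-membered aromatic ring of carbon only, and its reading of > 64000 nM suggests that such a ring need not strengthen inhibition. The expected change is therefore small, if anything toward stronger inhibition, and no larger than the usual scatter. The estimated step is an at least 1.1-fold lower number from compound 2 to compound 4 (0.06 log units; that floor lies within the scatter) in this assay on this reasoning. For compound 4 the estimated value is 55000 nM with an expected range from 20000 nM to 90000 nM in all.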

Compound 4, half-maximal inhibitory concentration: > 64000 nM
Compound 4 gave a limit, no number (the forecaster's own chance of this, stated with the estimate: 55%); middle value at least 1.1-fold (0.06 log units) away from the limit.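

In this assay no step can be read from compound 2 to compound 4; both readings are limits of the assay and not numbers. Compound 2 stands at: the limit of > 64000 nM in this assay, at which 3 of the 4 values shown sit.

The compounds shown leave open whether 4-fluorophenyl in place of trifluoromethyl on an aromatic carbon changes inhibition at all.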